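Piperidine to methylpiperazine on an inactive nitro sulfone amide

A few compounds are considered here, and "the series" means these few. Any claim that something is new, unique, unknown or untested is made for them only; others in the source may bear on it.

Compound 1, `CS(=O)(=O)c1ccc(C(=O)NCCC(=O)N2CCCCC2)cc1[N+](=O)[O-]`, in an assay on isolated protein for inhibition of thyroid hormone receptor beta (Homo sapiens), read by fluorescence polarization (on this read-out higher numbers stand for weaker inhibition and lower numbers for stronger inhibition), gives > 60000 nM, a limit of the assay and not a number.
Compound 2, `CS(=O)(=O)c1ccc(C(=O)NCC(=O)N2CCCCC2)cc1[N+](=O)[O-]`, in this assay gives > 60000 nM, again a limit rather than a number.

Going by the values given here, compound 2 therefore stands nowhere on a scale of numbers: its value is only a limit, and the one other value shown is a limit too. Among the compounds with values here, both rest at the limit of > 60000 nM in this assay, at which 2 of the 2 values shown sit, so no step between measured compounds can be described, and nothing about order or change between compound 1 and compound 2 can be said.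

Compound 3, `CN1CCN(C(=O)CNC(=O)c2ccc(S(C)(=O)=O)c([N+](=O)[O-])c2)CC1`, has not yet been measured. It differs from compound 2 by 4-methylpiperazin-1-yl in place of piperidin-1-yl on a carbonyl carbon. With both measured compounds sitting at a limit, no step size in this assay can be read from the data, and the expectation is that compound 3 also stays at or beyond that limit, with no movement beyond the scatter. For compound 3 in this assay the estimate is 80000 nM, with a range from 30000 nM to 250000 nM, which means an expected step that the limit leaves unreadable from compound 2 to compound 3.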

Compound 3, half-maximal inhibitory concentration: > 60000 nM
Compound 3 was reported as a limit; the forecaster's own chance of this, stated with the estimate: 85%; the middle value is on the limit's open side.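

In this assay compound 3 gives > 60000 nM, a limit of the assay and not a number. Compound 2 also stands at a limit, so no step can be read between compound 2 and compound 3, and all the values shown coincide: the limit of > 60000 nM in this assay, at which 3 of the 3 values shown sit.

The compounds shown leave open what measurable value, if any, this series can reach.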